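One Fluoro Group Fewer: Expected Shift in Acid Dissociation

A few compounds are considered here, and "the series" means these few. Any claim that something is new, unique, unknown or untested is made for them only; others in the source may bear on it.

Compound 1 `CCOC(=O)c1cc2cc(F)c(O)c(F)c2oc1=O`: 3.8
Compound 2 `O=C(O)c1cc2cc(F)c(O)c(F)c2oc1=O`: 3.7
Compound 3 `Cc1cc(=O)oc2c(F)c(O)c(F)cc12`: 4.7

In a physicochemical assay for acid dissociation, compound 3 gives the highest of these three values; compound 1 and compound 2 both sit lower, each beyond the scatter. Among the compounds with values here, the only measured step, a number 0.10 log units lower from compound 1 to compound 2 (within the scatter), concerns hydrogen in place of ethyl on an oxygen next to a carbonyl group and leaves the fluoro groups untouched, so it says nothing about them.

Compound 4 `Cc1cc(=O)oc2c(F)c(O)ccc12` differs from compound 3 by hydrogen in place of fluoro on an aromatic carbon. Within the data shown here, no measured step matches this change, so the expectation rests on the structural change alone. Compound 4 is expected to give 6, with a range from 5.2 to 6.8. The expected step of a number 1.30 log units higher from compound 3 to compound 4 (beyond the scatter) is therefore estimated to lie beyond the scatter, toward a proton given up less readily.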

Compound 4, acid dissociation constant: 6.4
Compound 4: the middle estimate sits 0.40 log units below what was measured, within the range that was stated.
By their numbers in this assay, from the lowest: compounds 2 and 1 (each within the scatter of the next); then compound 3; then compound 4.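

In this assay, hydrogen in place of fluoro on an aromatic carbon ortho to a hydroxy group gives a number 1.70 log units higher from compound 3 to compound 4 (beyond the scatter) and so moves the read-out toward a proton given up less readily. Within the data shown here, the only earlier step left the fluoro groups untouched, so this is the first sign that the read-out responds strongly to a change at this position. Nothing measured here explains the size of this step. Still open, on these data alone, is how a chlorine atom, a methoxy group or a nitrile would compare at this position. Also open, as far as these compounds go, is whether replacing the remaining fluoro group with hydrogen would give a step of similar size.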